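Working notes: cytotoxicity of three measured compounds and compound 4

A few compounds are considered here, and "the series" means these few. Any claim that something is new, unique, unknown or untested is made for them only; others in the source may bear on it.

Measured in an ADME assay on P3HR-1 cells (Homo sapiens) for cytotoxicity, read by microscopy and trypan blue exclusion, with a stated time of 2 days; a higher number here means that more compound is tolerated, a lower number that less compound is tolerated:
compound 1 `COc1cc([C@@H](O)[C@@H](C)Oc2ccc([C@@H]3O[C@H](c4ccc(O)c(OC)c4)[C@H](C)[C@H]3C)cc2OC)ccc1O`: 23200 nM.
compound 2 `COc1ccc([C@H]2O[C@@H](c3cc(OC)c(OC)c(OC)c3)[C@H](C)[C@@H]2C)cc1OC`: 172000 nM.
compound 3 `COc1cc([C@@H](OC(C)=O)[C@@H](C)Oc2c(OC)cc(/C=C/CO)cc2OC)cc(OC)c1OC`: reported only as a limit of the assay, > 200000 nM.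

Compound 3 stands at the top of what has been recorded, at the limit of > 200000 nM in this assay, at which 1 of the 3 values shown sits; for it there is no number, only the limit. Compound 1 and compound 2 are the two with actual numbers, compound 1 sitting at the lower figure of the two. Within the data shown here, no pair among the measured compounds differs in a single place, so no measured step sets a scale for the change that follows.

Compound 4 `C=CCc1cc(OC)c(O[C@H](C)[C@H](OC(C)=O)c2cc(OC)c(OC)c(OC)c2)c(OC)c1` is reached from compound 3 by one change on an aromatic carbon of the shared core: allyl in place of 3-hydroxyprop-1-en-1-yl on an aromatic carbon. With compound 3 already at the limit, the step in this assay is expected to be none beyond the scatter, and is estimated as a number no higher from compound 3 to compound 4 (the limit leaves the size open). Compound 4 is therefore expected to give about 200000 nM, in the range 100000 nM to 400000 nM, and is likely to be reported again as a limit rather than a number.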

Compound 4, half-maximal cytotoxic concentration: 85000 nM
Beside the measured number, compound 4's estimate is 2.4-fold (0.37 log units) above it; measured number below the stated range.
By their numbers in this assay, from the lowest: compound 1; then compound 4; then compound 2. At a limit, above all of these: compound 3.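

In this assay, allyl in place of 3-hydroxyprop-1-en-1-yl on an aromatic carbon, para to a large group, gives an at least 2.3-fold lower number from compound 3 to compound 4 (0.37 log units; beyond the scatter). Among these compounds, this is the only single-place change in the set, and it shows that less compound is tolerated after this swap, so this position is not silent in this read-out. The value of compound 3 is a limit and not a number, so the step has a lower bound only and its full size stays open: the limit of > 200000 nM in this assay, at which 1 of the 4 values shown sits.

One pair cannot separate the loss of the terminal hydroxyl from the shift of the double bond, and nothing shown assigns a cause to the step. As far as these compounds go, how an amine, a carboxylic acid or a longer chain on this aromatic carbon would read remains open, as does whether the step carries over to the core of compound 1.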